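Chloro for Fluoro: a Small Step Repeated

A few compounds are considered here, and "the series" means these few. Any claim that something is new, unique, unknown or untested is made for them only; others in the source may bear on it.

Measured compounds:
compound 1 `O=C(/C=C\Nc1ccc(Cl)cc1)c1cn(-c2ccccc2)nc1-c1ccc(F)cc1` — 21300 nM
compound 2 `O=C(/C=C\Nc1ccc(Cl)cc1)c1cn(-c2ccccc2)nc1-c1ccc(Cl)cc1` — 23400 nM
compound 3 `COc1cc(-c2nn(-c3ccccc3)cc2C(=O)/C=C\Nc2ccc(F)cc2)cc(OC)c1OC` — 25700 nM

In an ADME assay on HaCaT cells (Homo sapiens) for antiproliferative activity, read by MTT assay, with a stated time of 48 h (on this read-out lower numbers stand for stronger inhibition and higher numbers for weaker inhibition), compound 1 gives 21300 nM and compound 2 gives 23400 nM. The change between them is chloro in place of fluoro on an aromatic carbon, and it produced a 1.1-fold higher number from compound 1 to compound 2 (0.04 log units; within the scatter). Compound 3, which gives 25700 nM in this assay, carries a different core; how the core of compound 3 differs from that of compound 1 is not broken down here. Compound 4 `COc1cc(-c2nn(-c3ccccc3)cc2C(=O)/C=C\Nc2ccc(Cl)cc2)cc(OC)c1OC` has not yet been measured. Going by the values given here, it differs from compound 3 by chloro in place of fluoro on an aromatic carbon, the same change, at the same kind of place, as the one from compound 1 to compound 2, read one bond further out as (4-fluorophenyl)amino to (4-chlorophenyl)amino.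

Since that change moved compound 1 to compound 2 by only a step within the scatter, a step of similar size is expected here, and compound 4 is estimated to show a 1.1-fold higher number from compound 3 to compound 4 (0.02 log units; within the scatter) in this assay. On this basis compound 4 is expected to give about 27000 nM, between 14000 nM and 52000 nM.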

Compound 4, half-maximal inhibitory concentration: 30200 nM
Estimate against measurement, compound 4: 1.1-fold (0.05 log units) below; low and high end bracket the measured number.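

In this assay, chloro in place of fluoro on an aromatic carbon gave a 1.2-fold higher number from compound 3 to compound 4 (0.07 log units; within the scatter). Set beside the earlier step, the change reads alike on the two cores: the same change on two cores in this assay, a 1.1-fold higher number (0.04 log units; within the scatter) from compound 1 to compound 2 and a 1.2-fold higher number (0.07 log units; within the scatter) from compound 3 to compound 4, 1.1-fold (0.03 log units) apart, within the scatter of two such steps. So in this series the exchange can be carried from one of these cores to the other with no difference that the assay can resolve, but neither step is beyond the scatter, so the pairs do not show that the change has any real effect of its own, and two pairs say nothing about a third core or about any other assay.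

The compounds shown leave open whether a group other than the two halogens on the aromatic carbon, such as an amine, a nitrile or a carboxylic acid, would move the number beyond the scatter. They also leave open whether replacing the phenyl group that all four compounds share would alter the picture.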